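A few compounds are considered here, and "the series" means these few. Any claim that something is new, unique, unknown or untested is made for them only; others in the source may bear on it.

Compound 1 `COc1ccc2c(c1)c(C=O)cn2Cc1cn([C@@H]2O[C@H](COC(C)=O)[C@@H](OC(C)=O)[C@H](OC(C)=O)[C@H]2OC(C)=O)nn1` and compound 2 `CC(=O)OC[C@H]1O[C@@H](n2cc(Cn3cc(/C=C4/C(=O)Nc5ccc(F)cc54)c4ccccc43)nn2)[C@H](OC(C)=O)[C@@H](OC(C)=O)[C@@H]1OC(C)=O` share a sugar-bearing core and differ in the group hanging from the indole. Compound 1 sits at the limit of > 200000 nM in this assay, at which 1 of the 2 values shown sits, so in an ADME assay on NIH3T3 cells (Homo sapiens) for cytotoxicity, read by sulforhodamine B assay, with a stated time of 48 h (a lower number here means a stronger inhibitor, a higher number a weaker inhibitor), compound 1 is recorded only as a limit, > 200000 nM. In this assay, among the measured compounds shown here, compound 2 gives 62500 nM, the single measured number here. Compound 3 `COc1ccc2c(c1)c(/C=C1/C(=O)Nc3ccc(F)cc31)cn2Cc1cn([C@@H]2O[C@H](COC(C)=O)[C@@H](OC(C)=O)[C@H](OC(C)=O)[C@H]2OC(C)=O)nn1` is compound 2 with one change: methoxy in place of hydrogen on an aromatic carbon. For the measured compounds named here, no measured pair isolates this change, so the expected step of a 1.0-fold lower number from compound 2 to compound 3 (0.02 log units; within the scatter) is small, with no direction beyond the scatter. Compound 3 is therefore expected to give 60000 nM in this assay, with a likely range from 20000 nM to 200000 nM.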

Compound 3, half-maximal inhibitory concentration: > 200000 nM
Compound 3 was reported as a limit (the forecaster's own chance of this, stated with the estimate: 20%); at least 3.3-fold (0.52 log units) between middle value and limit.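

Among the compounds shown here, on the shared core, methoxy in place of hydrogen on an aromatic carbon gives the first readable single change in this assay: an at least 3.2-fold higher number from compound 2 to compound 3 (0.50 log units; beyond the scatter) for this swap, on a ring carbon meta to a fused ring and para to a fused ring. The true size of this step may be larger, because compound 3 is recorded only as a limit: the limit of > 200000 nM in this assay, at which 2 of the 3 values shown sit. The step between compound 1 and compound 3 cannot be read, as both are limits.

This rests on a single pair of compounds. As far as these compounds go, whether an amine, a hydroxyl or a longer ethoxy chain at this place would give a measurable number remains open.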